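The compounds below may be only part of what the source reports. "The series", "measured", "known", "first", "only" and "open" are said of these compounds alone.

Working notes on the series. Within the data shown here, compound 1 `CC(C)(C)OC(=O)n1cc(-c2ccc(NC(=O)c3ccco3)cc2)nc1N` is the first member of one core in an assay on isolated protein for inhibition of sodium channel protein type 4 subunit alpha (Homo sapiens), read by electrophysiology, with a stated time of 4 min; a lower number here means a stronger inhibitor, a higher number a weaker inhibitor. In this assay compound 1 gives only a limit of the assay, > 30000 nM. Compound 2 `CC(C)(C)OC(=O)n1cc(-c2ccc(NC(=O)c3cc4ccccc4[nH]3)cc2)nc1N` differs from compound 1 by 1H-indol-2-yl in place of furan-2-yl on a carbonyl carbon. In this assay compound 2 likewise returns only a limit, > 30000 nM. The step that the two limits leave unreadable from compound 1 to compound 2 cannot be sized because of the limit of > 30000 nM in this assay, at which 3 of the 3 values shown sit. Compound 3 `CNc1nc(-c2cccc(NC(=O)c3ccco3)c2)cn1C(=O)OC(C)(C)C` belongs to a second core; the difference between the two cores is not broken down here. In this assay compound 3 also reaches only a limit, > 30000 nM. Among the measured compounds shown here, compound 4 `CNc1nc(-c2cccc(NC(=O)c3cc4ccccc4[nH]3)c2)cn1C(=O)OC(C)(C)C` is not yet measured and differs from compound 3 by 1H-indol-2-yl in place of furan-2-yl on a carbonyl carbon, the same change as the one from compound 1 to compound 2, at the same place. For compound 4 in this assay the expected value is 50000 nM, with an expected range from 20000 nM to 200000 nM, and most probably again only a limit. For the measured compounds named here, the expected step that the limit leaves unreadable from compound 3 to compound 4 rests on a step that the two limits leave unreadable from compound 1 to compound 2 being unreadable and on (the limit of > 30000 nM in this assay, at which 3 of the 3 values shown sit), where every value so far sits.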

Compound 4, half-maximal inhibitory concentration: > 30000 nM
Compound 4: only a limit was reported; the forecaster's own chance of this, stated with the estimate: 85%; the middle value does not contradict the limit.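

In this assay compound 4 gives only a limit, > 30000 nM. No size can be read for the change from compound 3 to compound 4, nor for that from compound 1 to compound 2: the limit of > 30000 nM in this assay, at which 4 of the 4 values shown sit. The compounds shown leave open whether 1H-indol-2-yl in place of furan-2-yl changes inhibition on either core.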